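Phenyl for methoxy on two flavone anilide cores

The source may hold more compounds than are shown below. What is called first, only, known or untested is meant among the compounds shown, and "the series" means these compounds.

The set comprises compound 1 `COc1ccc(NC(=O)COc2ccc3oc(-c4ccccc4)cc(=O)c3c2)cc1`, compound 2 `O=C(COc1ccc2oc(-c3ccccc3)cc(=O)c2c1)Nc1ccc(-c2ccccc2)cc1`, compound 3 `COc1ccc(NC(=O)COc2ccc3c(=O)cc(-c4ccccc4)oc3c2)cc1` and the not yet measured compound 4 `O=C(COc1ccc2c(=O)cc(-c3ccccc3)oc2c1)Nc1ccc(-c2ccccc2)cc1`. In a functional assay on MT2 cells (Homo sapiens) for antiproliferative activity, read by MTT assay, with a stated time of 72 h (a higher number here means a weaker inhibitor of growth, a lower number a stronger inhibitor of growth), compound 1 gives 3010 nM. Compound 2 reaches only the limit of this assay, > 10000 nM, so no number is known for it. Going an at least 3.3-fold higher number from compound 1 to compound 2 (0.52 log units; beyond the scatter), the change being (phenyl in place of methoxy on an aromatic carbon). Compound 3 shares its atoms with compound 1 but joins them differently; the difference between the two cores is not broken down here. In this assay compound 3 gives 6700 nM, a higher number than compound 1 shows.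

Compound 4 relates to compound 3 exactly as compound 2 relates to compound 1: phenyl in place of methoxy on an aromatic carbon. Because that same change gave an at least 3.3-fold higher number from compound 1 to compound 2 (0.52 log units; beyond the scatter), and because compound 3 already starts from 6700 nM, the step from compound 3 to compound 4 is expected to be a 3.3-fold higher number from compound 3 to compound 4 (0.52 log units; beyond the scatter). Compound 4 is therefore estimated at 22000 nM, in a range from 8000 nM to 60000 nM, with a real chance that the assay reports only its limit.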

Compound 4, concentration for 50% growth inhibition: 2480 nM
Compound 4: middle estimate off by 8.9-fold (0.95 log units), on the high side, and the stated range ends above it.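

In this assay, phenyl in place of methoxy on an aromatic carbon gives a 2.7-fold lower number from compound 3 to compound 4 (0.43 log units; beyond the scatter), so on this core the number moves in the opposite direction to the one seen on the core of compound 1. The two steps do not agree, and the gap between them is larger than scatter alone would account for: the same change on two cores in this assay, an at least 3.3-fold higher number (0.52 log units; beyond the scatter) from compound 1 to compound 2 and a 2.7-fold lower number (0.43 log units; beyond the scatter) from compound 3 to compound 4, at least 8.9-fold (0.95 log units) apart, beyond the scatter of two such steps This shows that, in these two pairs, the direction of the change did not carry over from one core to the other, but it does not show why, and the true size of the earlier step remains unknown, as compound 2 stands only at a limit: the limit of > 10000 nM in this assay, at which 1 of the 4 values shown sits.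

Left open is whether other groups at that place, such as a chlorine, an amine or a carboxylic acid, would follow the pattern of one core or the other. Also open, from the compounds shown here alone, is whether a longer chain between the amide and the core would preserve the difference between the two cores.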